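From methyl to 4-vinylphenyl on the sulfonyl sulfur

The source may report more compounds than this note shows. Statements on the series, on what has been measured and on what is new or still open speak of the compounds shown alone.

Working notes on four sulfonamides with a shared core: compound 1 `Cc1ccc(S(=O)(=O)Nc2ccc(-c3nc4ccccc4o3)cc2)cc1`, compound 2 `O=S(=O)(Nc1ccc(-c2nc3ccccc3o2)cc1)c1ccc(Cl)s1`, compound 3 `CS(=O)(=O)Nc1ccc(-c2nc3ccccc3o2)cc1` and the unmeasured compound 4 `C=Cc1ccc(S(=O)(=O)Nc2ccc(-c3nc4ccccc4o3)cc2)cc1`.

In an ADME assay on HEK293 cells (Homo sapiens) for cytotoxicity, read by resazurin assay, with a stated time of 48 h (on this read-out higher numbers stand for lower toxicity in this test and lower numbers for higher toxicity in this test), compound 1 gives 88000 nM. Compound 2 reads > 100000 nM, which is a limit. Compound 3 reads > 100000 nM, also a limit, and so sits at the limit of > 100000 nM in this assay, at which 2 of the 3 values shown sit.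

The step to compound 4 is 4-vinylphenyl in place of methyl on a sulfonyl sulfur.

The closest measured step is an at least 1.1-fold higher number from compound 1 to compound 3 (0.05 log units; that floor lies within the scatter), which exchanges methyl and 4-methylphenyl on the same sulfur and here has to be read in reverse. Its floor lies within the scatter. The step of an at least 1.1-fold higher number from compound 1 to compound 2 (0.05 log units; that floor lies within the scatter) also has a floor within the scatter, and a step that the two limits leave unreadable from compound 2 to compound 3 cannot be read at all. Among the compounds with values here, the only number belongs to compound 1, which carries 4-methylphenyl and gives 88000 nM, so that value anchors the expectation.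

The expected result is an at least 1.2-fold lower number from compound 3 to compound 4 (0.09 log units; that floor lies within the scatter), toward a lower number if it shows at all and not clearly beyond the scatter. For compound 4 the estimate is 80000 nM, with an expected range of 35000 nM to 130000 nM.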

Compound 4, half-maximal cytotoxic concentration: > 100000 nM
Compound 4: only a limit was reported; the forecaster's own chance of this, stated with the estimate: 40%; middle value at least 1.2-fold (0.09 log units) away from the limit.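

In this assay compound 4 gives > 100000 nM, which is a limit. Methyl, 5-chlorothiophen-2-yl and 4-vinylphenyl on the sulfonyl sulfur now all sit at this same limit, so adding a six-membered aromatic ring of carbon only and a double bond outside aromatic rings gives no number for this position: the limit of > 100000 nM in this assay, at which 3 of the 4 values shown sit. Within the data shown here, the one readable step, vinyl in place of methyl on an aromatic carbon, is an at least 1.1-fold higher number from compound 1 to compound 4 (0.05 log units; that floor lies within the scatter), while the steps to compound 4 from compound 2 and from compound 3 cannot be read.

Going by these compounds, how compound 2, compound 3 and compound 4 stand relative to one another remains open, since none of the three has a number in this assay. Also open, on these data alone, is whether an amine or a carboxylic acid in place of the vinyl on an aromatic carbon would give a reading clearly apart from that of compound 1, 88000 nM.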